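Swapping chloro for cyano on an inactive compound

The source may report more compounds than this note shows. Statements on the series, on what has been measured and on what is new or still open speak of the compounds shown alone.

Compound 1 `COC(=O)c1cccc(-c2ccc(-n3cccc3)nn2)c1` gives > 25000 nM (a limit)
Compound 2 `COc1ccc(Nc2ccc(-c3ccccc3)nn2)cc1` gives > 25000 nM (a limit)
Compound 3 `CCN(CC)c1ccc(-c2cccc(Cl)c2)nn1` gives > 25000 nM (a limit)

All three entries come from a functional assay on MDA-MB-231 cells (Homo sapiens) for antiproliferative activity, with a stated time of 48 h (on this read-out higher numbers stand for weaker inhibition and lower numbers for stronger inhibition), and none of them is an exact number. Compound 3 stands at the limit > 25000 nM and so has no measured potency to compare against. Within the data shown here, it is no exception within the set, as the overall picture is the limit of > 25000 nM in this assay, at which 3 of the 3 values shown sit, and no compound has yet given a real number.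

The next compound to be tested is compound 4 `CCN(CC)c1ccc(-c2cccc(C#N)c2)nn1`. It differs from compound 3 in one place only, with cyano in place of chloro on an aromatic carbon, meta to a large group (cyano in place of chloro on an aromatic carbon). Among the measured compounds shown here, no two measured compounds differ by a single change, so the data do not show how large one such change can be in this assay. The starting point is compound 3 at the limit > 25000 nM and nothing there points to a gain. No step beyond the usual scatter is therefore expected, and the estimated change is a step that the limit leaves unreadable from compound 3 to compound 4 in size. For compound 4 the expected value is 28000 nM within an estimated range of 10000 nM to 60000 nM and a report of only a limit is the likeliest outcome.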

Compound 4, half-maximal inhibitory concentration: > 25000 nM
Compound 4: no number, only a limit; the forecaster's own chance of this, stated with the estimate: 75%; the middle value does not contradict the limit.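

Compound 3 and compound 4 both stop at a limit rather than a real number, so the size of the swap from chloro to cyano cannot be read. The compounds shown leave open which structural change, if any, would bring a measurable potency, and the overall picture stays as it was: the limit of > 25000 nM in this assay, at which 4 of the 4 values shown sit.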